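The source may hold more compounds than are shown below. What is called first, only, known or untested is meant among the compounds shown, and "the series" means these compounds.

Working notes on the series. In a functional assay on MCF7 cells (Homo sapiens) for antiproliferative activity, read by MTT assay (a higher number here means a weaker inhibitor, a lower number a stronger inhibitor), compound 1 (`Cc1cccc(Nc2nccc(-c3ccc(Br)cc3)n2)c1`) gives 210000 nM and compound 2 (`O=[N+]([O-])c1ccc(Nc2nccc(-c3ccc(Br)cc3)n2)cc1`) gives 681000 nM as the higher of the two numbers. Compound 2 is thus the weaker of the pair, by a gap beyond the usual scatter. Compound 3 (`Clc1ccc(Nc2nccc(-c3ccc(Br)cc3)n2)cc1`) has chloro in place of nitro on an aromatic carbon, para to a large group (chloro in place of nitro on an aromatic carbon). Going by the values given here, no measured pair differs in one place only, so the size of this step in this assay cannot be read directly from the series. Among the compounds with values here, the only guide is thin: compound 1 (210000 nM), the one measured compound without nitro, has the lower number. A modest fall in the number is expected, estimated as a 2.7-fold lower number from compound 2 to compound 3 (0.44 log units; beyond the scatter) and possibly not much beyond the scatter. For compound 3 the estimated value is 250000 nM (expected range 80000 nM to 700000 nM).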

Compound 3, half-maximal inhibitory concentration: 4180 nM
Estimate against measurement, compound 3: 60-fold (1.78 log units) above; the measured number lies below the stated range.
By their numbers in this assay, from the lowest: compound 3; then compound 1; then compound 2.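

In this assay the aromatic carbon para to a large group turns out to be highly sensitive to what it carries: chloro in place of nitro brings a 160-fold lower number from compound 2 to compound 3 (2.21 log units; beyond the scatter) and puts compound 3 clearly lowest of the three. The change of 4-chlorophenyl in place of 3-methylphenyl on a nitrogen on an aromatic ring brings a 50-fold lower number from compound 1 to compound 3 (1.70 log units; beyond the scatter) as well, so neither earlier compound hinted at a number this low. Nothing available here accounts for the size of either step.

On these data alone, whether the low number is particular to chloro remains open, since the series shows only nitro and chloro at this carbon. How fluoro, methoxy, an amine or a carboxylic acid would read at the same carbon is also undecided.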